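Swapping a cyclopropylamino for 4-methylpiperazin-1-yl

The compounds below may be only part of what the source reports. "The series", "measured", "known", "first", "only" and "open" are said of these compounds alone.

The set holds three compounds. Compound 1 `CCN(CC)CC(=O)N1N=C(C)CC1c1ccccc1OC(C)=O` gives 29500 nM in a functional assay on MGC-803 cells (Homo sapiens) for cytotoxicity, read by MTT assay, with a stated time of 48 h; a higher number here means a weaker inhibitor, a lower number a stronger inhibitor. Compound 2 `O=C(CNC1CC1)N1N=C(c2cc3ccccc3oc2=O)CC1c1ccccc1` is recorded in this assay as "not active" (no number reported), so no single number stands for it. Compound 3 `CN1CCN(CC(=O)N2N=C(c3cc4ccccc4oc3=O)CC2c2ccccc2)CC1` remains to be measured; it differs from compound 2 in one place: 4-methylpiperazin-1-yl in place of cyclopropylamino on a saturated chain carbon bound to a carbonyl carbon. Going by the values given here, no step between measured compounds sharing this core is available, so the change gives no guide to size or direction beyond the scatter of this assay. Compound 3 is expected to remain weak, estimated at 40000 nM with a range of 10000 nM to 150000 nM, and a report of no activity is quite possible.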

Compound 3, half-maximal inhibitory concentration: 46100 nM
The estimate for compound 3 lay 1.2-fold (0.06 log units) below the measured number; measured number inside the range.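

Going by these compounds alone, compound 2 carries no number, so no step from it to compound 3 can be read. The compounds shown leave open what swapping cyclopropylamino for 4-methylpiperazin-1-yl does to potency on this core. No further evidence bears on the result.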